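The source may hold more compounds than are shown below. What is called first, only, known or untested is meant among the compounds shown, and "the series" means these compounds.

Compound 1 `O=S(=O)(c1cc(Cl)cc(Cl)c1)c1cnc2cc(F)ccc2c1-c1ccc(Cl)cc1` and compound 2 `COc1ccc(S(=O)(=O)c2cnc3cc(F)ccc3c2-c2ccc(Cl)cc2)cc1` share a core and differ by one change, (4-methoxyphenyl in place of 3,5-dichlorophenyl on a sulfonyl sulfur). In an ADME assay on microsomes from liver (Homo sapiens) for metabolic stability, tested at 2.5 uM (on this read-out lower numbers stand for slow clearance and higher numbers for fast clearance), compound 1 gives 0.13 mL/min, and compound 2 gives 1.28 mL/min, a step of a 9.8-fold higher number from compound 1 to compound 2 (0.99 log units; beyond the scatter). Compound 3 `COc1ccc(-c2c(S(=O)(=O)c3cc(Cl)cc(Cl)c3)cnc3c(F)cccc23)cc1` has a different core; how the two cores differ is not broken down here. In this assay compound 3 gives 2.11 mL/min. Compound 4 `COc1ccc(-c2c(S(=O)(=O)c3ccc(OC)cc3)cnc3c(F)cccc23)cc1` arises from compound 3 by the same change, (4-methoxyphenyl in place of 3,5-dichlorophenyl on a sulfonyl sulfur). Because the earlier step of a 9.8-fold higher number from compound 1 to compound 2 (0.99 log units; beyond the scatter) was clearly beyond the scatter, a step of similar size is expected from compound 3 to compound 4, namely a 7.1-fold higher number from compound 3 to compound 4 (0.85 log units; beyond the scatter). On that basis compound 4 is estimated at 15 mL/min, with a likely range from 6 mL/min to 40 mL/min.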

Compound 4, intrinsic clearance in a liver preparation (reported as CLH), per the amount of preparation that the assay uses: 2.12 mL/min
Beside the measured number, compound 4's estimate is 7.1-fold (0.85 log units) above it, outside the stated range (below it).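

In this assay, the change from 3,5-dichlorophenyl to 4-methoxyphenyl on a sulfonyl sulfur does not carry over unchanged from one core to the other: the same change on two cores in this assay, a 9.8-fold higher number (0.99 log units; beyond the scatter) from compound 1 to compound 2 and a 1.0-fold higher number (0.00 log units; within the scatter) from compound 3 to compound 4, 9.8-fold (0.99 log units) apart, beyond the scatter of two such steps. The new step is a 1.0-fold higher number from compound 3 to compound 4 (0.00 log units; within the scatter), so on this second core the change leaves no difference that can be told from the scatter. With one pair on each core, this shows that the size of the step differs between these two cores, but it does not show which difference between the cores goes with that, or how the change would behave on any other core. The compounds shown leave open how an amine or a carboxylic acid in place of these aryl groups on the sulfonyl sulfur would read in this assay.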